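Sulfonyl aryl change on the compound at the limit

The compounds below may be only part of what the source reports. "The series", "measured", "known", "first", "only" and "open" are said of these compounds alone.

In an ADME assay on HEK-293T cells (Homo sapiens) for cytotoxicity, read by MTT assay, with a stated time of 24 h (a higher number here means that more compound is tolerated, a lower number that less compound is tolerated), compound 2 (`O=S(=O)(c1ccccc1)n1c(-c2cn(-c3ccccc3)nc2-c2ccc(C(F)(F)F)cc2)nc2ccccc21`) gives 128000 nM. Compound 3 (`COc1ccc(S(=O)(=O)n2c(-c3cn(-c4ccccc4)nc3-c3ccc(C(F)(F)F)cc3)nc3ccccc32)cc1`) gives > 300000 nM, which is a limit and not a number. Compound 4 (`Cc1ccc(C)c(S(=O)(=O)n2c(-c3cn(-c4ccccc4)nc3-c3ccc(C(F)(F)F)cc3)nc3ccccc32)c1`) differs from compound 3 as follows: 2,5-dimethylphenyl in place of 4-methoxyphenyl on a sulfonyl sulfur. In words, 2,5-dimethylphenyl stands in place of 4-methoxyphenyl on a sulfonyl sulfur. Within the data shown here, one measured step bears on this: methoxy in place of hydrogen on an aromatic carbon gave an at least 2.3-fold higher number from compound 2 to compound 3 (0.36 log units; beyond the scatter), and compound 4 carries no methoxy. Compound 1 (`Cc1ccc(-c2nn(-c3ccccc3)cc2-c2nc3ccccc3n2S(=O)(=O)c2cc(C)ccc2C)cc1`), with the same 2,5-dimethylphenyl, gives 82200 nM. A lower number is therefore expected in this assay, with an estimated size of an at least 2.6-fold lower number from compound 3 to compound 4 (0.41 log units; beyond the scatter). For compound 4 the estimated value is 115000 nM, within an expected range of 55000 nM to 240000 nM.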

Compound 4, half-maximal cytotoxic concentration: 223000 nM
Compound 4: the middle estimate sits 1.9-fold (0.29 log units) below what was measured; the range from low to high includes it.
By their numbers in this assay, from the lowest: compounds 1, 2 and 4 (each within the scatter of the next, the first and the last beyond it). At a limit, above all of these: compound 3.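

In this assay, 2,5-dimethylphenyl in place of phenyl on a sulfonyl sulfur gives a 1.7-fold higher number from compound 2 to compound 4 (0.24 log units; within the scatter), a step that lies within the scatter. Trifluoromethyl in place of methyl on an aromatic carbon, with 2,5-dimethylphenyl held constant, reads a 2.7-fold higher number from compound 1 to compound 4 (0.43 log units; beyond the scatter), a modest step at a different place. Compound 3 carries a limit and not a number: the limit of > 300000 nM in this assay, at which 1 of the 4 values shown sits 2,5-dimethylphenyl in place of 4-methoxyphenyl on a sulfonyl sulfur gives an at least 1.3-fold lower number from compound 3 to compound 4 (0.12 log units; that floor lies within the scatter), and that floor is all this step shows.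

Open, going by these compounds, is how a sulfonyl aryl bearing an amine or a carboxylic acid would read in this assay.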